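The source may report more compounds than this note shows. Statements on the series, on what has been measured and on what is new or still open speak of the compounds shown alone.

Measured in an assay on cells for agonist activity at D(4) dopamine receptor (Homo sapiens), read by luminescence and beta-arrestin recruitment, with a stated time of 90 min; a higher number here means that more compound is needed for the effect, a lower number that less compound is needed:
- compound 1, `CCc1cccc(NC(=O)CN2CCN(c3ccccn3)CC2)c1`: 133 nM
- compound 2, `CCc1cccc(NC(=O)CN2CCN(c3ccc(Cl)cn3)CC2)c1`: "not active" (no number reported)

Compound 1 gives a numerical half-maximal effective concentration in this assay. Compound 2 differs from compound 1 in carrying a chlorine on the pyridyl ring of the piperazine. In this assay, within the data shown here, compound 2 is reported only as "not active" (no number reported); no number stands for compound 2, so no step between compound 1 and compound 2 can be sized, and compound 2 cannot be placed on a scale beyond the statement that it gave no measurable effect.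

Compound 3, `O=C(CN1CCN(c2ccc(Cl)cn2)CC1)Nc1cncnc1`, keeps the chloropyridyl piperazine and the acetamide linker of compound 2 and changes the amide substituent: pyrimidin-5-yl in place of 3-ethylphenyl on an amide-type nitrogen. Among the measured compounds shown here, no step between measured compounds exists for this kind of change, so the direction cannot be read from the series. The starting point, compound 2, has no recorded activity in this assay, and the change to compound 3 leaves that part of the molecule untouched. Compound 3 is therefore expected to remain without a measurable half-maximal effective concentration, or at best to show a weak one; the estimate for compound 3 in this assay is 10000 nM, with a range from 2000 nM to 50000 nM, and the most likely outcome is that only a limit is reported.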

Compound 3, half-maximal effective concentration: "not active" (no number reported)
No number was reported for compound 3, and the estimate cannot be compared.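

Compound 2 and compound 3 are both reported in this assay without a number, so no step can be read between them. No supporting data bear on this result. The compounds shown leave open how 3-ethylphenyl and pyrimidin-5-yl on the amide-type nitrogen compare where the chlorine-free pyridyl piperazine of compound 1 is kept.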